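Cyclopropylamino to propylamino in the cytotoxicity series

A few compounds are considered here, and "the series" means these few. Any claim that something is new, unique, unknown or untested is made for them only; others in the source may bear on it.

Compound 3 `OC[C@H]1C[C@@H](Cn2cnc3c(NC4CC4)ncnc32)c2ccccc21` gives no number in an ADME assay on L1210/0 cells (Mus musculus) for cytotoxicity, with a stated time of 48 h (a higher number here means a weaker inhibitor, a lower number a stronger inhibitor), only the limit > 200000 nM. In this assay compound 1 `OC[C@H]1C[C@@H](Cn2cnc3c(-c4ccc(Cl)cc4)ncnc32)c2ccccc21` gives 8440 nM and compound 2 `Cc1ccc(-c2ncnc3c2ncn3C[C@@H]2C[C@H](CO)c3ccccc32)cc1` gives 15400 nM, and a 1.8-fold higher number from compound 1 to compound 2 (0.26 log units; within the scatter) shows that pair to be level. Exchanging either aryl group for cyclopropylamino produced large steps: an at least 23-fold higher number from compound 1 to compound 3 (1.37 log units; beyond the scatter) and an at least 12-fold higher number from compound 2 to compound 3 (1.11 log units; beyond the scatter). Both are bounded by the limit, so their true size is open.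

Compound 4 `CCCNc1ncnc2c1ncn2C[C@@H]1C[C@H](CO)c2ccccc21` carries propyl in place of cyclopropyl on a nitrogen on an aromatic ring. Going by the values given here, no measured step alters this group alone, so the evidence is indirect. The two large steps concern the loss of the aryl group, and compound 4 lacks that group as well. It should therefore stay with compound 3 at the weak end of the series. Only a small change is expected, as an at least 1.3-fold lower number from compound 3 to compound 4 (0.12 log units; that floor lies within the scatter), and the assay may again report only a limit. Compound 4 is estimated at 150000 nM, with an expected range of 50000 nM to 200000 nM.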

Compound 4, half-maximal inhibitory concentration: > 200000 nM
Compound 4 ended at the assay's limit (the forecaster's own chance of this, stated with the estimate: 55%); middle value at least 1.3-fold (0.12 log units) away from the limit.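

In this assay compound 4 gives > 200000 nM as a limit of the assay, not a number. Propylamino thus behaves like cyclopropylamino in this series: the open chain, like the three-membered ring, leaves the value at the limit, with an at least 12-fold higher number from compound 2 to compound 4 (1.11 log units; beyond the scatter) and an at least 23-fold higher number from compound 1 to compound 4 (1.37 log units; beyond the scatter) for the exchange of the aryl group. The step between the two amino compounds cannot be read: the limit of > 200000 nM in this assay, at which 2 of the 4 values shown sit.

From the compounds shown here alone, the true size of all the steps from the aryl compounds to the amino compounds stays open, and so does any difference between cyclopropylamino and propylamino. Also open, going by these compounds, is whether a longer chain on the nitrogen, a benzylamino group or an unsubstituted phenyl on the same aromatic carbon would give a readable value.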